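Butylsulfanyl in Place of Butoxy on the Shared Core

This account rests on a few compounds, and the source may have more. Where it says the series, first, only, none or still open, it means among the compounds named here.

Compound 2 `CCCCOc1nc(N)c2ncn([C@@H]3O[C@H](COP(=O)(O)OP(=O)(O)OP(=O)(O)O)[C@@H](O)[C@H]3O)c2n1` carries a butoxy group on its purine-like core. Among the compounds with values here, in an assay on cell membranes with P2Y purinoceptor 1 (Meleagris gallopavo) as the target (on this read-out lower numbers stand for an effect already at smaller amounts and higher numbers for an effect only at larger amounts of compound), compound 2 gives 88 nM, the higher of the two numbers measured so far. Its nearest neighbour is compound 1 `CCCCNc1nc(N)c2ncn([C@@H]3O[C@H](COP(=O)(O)OP(=O)(O)OP(=O)(O)O)[C@@H](O)[C@H]3O)c2n1`, which differs only in bearing a butylamino group in the same place; in this assay compound 1 gives 39 nM. Within the data shown here, the single measured step, a 2.3-fold higher number from compound 1 to compound 2 (0.35 log units; beyond the scatter), is the only one that bears on the present question, and it shows that swapping the atom that links the butyl chain to the core moves the number only modestly.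

Compound 3 `CCCCSc1nc(N)c2ncn([C@@H]3O[C@H](COP(=O)(O)OP(=O)(O)OP(=O)(O)O)[C@@H](O)[C@H]3O)c2n1` is not yet measured in this assay. It arises from compound 2 by butylsulfanyl in place of butoxy on an aromatic carbon. Among the measured compounds shown here, since the one comparable exchange of the linking atom gave a modest shift, the step to compound 3 is expected to be small as well, with no firm direction, and the estimate is a 1.6-fold lower number from compound 2 to compound 3 (0.20 log units; within the scatter). Compound 3 is therefore estimated to give about 55 nM in this assay, with a range from 15 nM to 200 nM.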

Compound 3, half-maximal effective concentration: 18 nM
For compound 3 the middle estimate is 3.1-fold (0.49 log units) above the measured one, within the range that was stated.
By their numbers in this assay, from the lowest: compound 3; then compound 1; then compound 2.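

Exchanging butoxy for butylsulfanyl on this aromatic carbon gives a 4.9-fold lower number from compound 2 to compound 3 (0.69 log units; beyond the scatter) in this assay and so shows that the position also responds to a sulfur link, which the earlier pair of nitrogen and oxygen links could not show. Butylsulfanyl also separates from butylamino, with a 2.2-fold lower number from compound 1 to compound 3 (0.34 log units; beyond the scatter) and the same butyl chain on the shared core. Together with a 2.3-fold higher number from compound 1 to compound 2 (0.35 log units; beyond the scatter) as the earlier step, this gives an order for the three links, all steps beyond the scatter: compound 3 has the lowest number, compound 1 the middle one and compound 2 the highest. The compounds shown offer no measurement that would account for this order, so the result stands as an observation only.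

Going by these compounds, it remains open whether the same order of sulfur, nitrogen and oxygen links would hold with a longer chain such as hexyl or a shorter one such as ethyl in place of butyl. Also open, on these data alone, is how a ring such as cyclohexyl on the sulfur would compare with the butyl chain of compound 3 in this assay on this core.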